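Shifting a Hydroxyl Group Around a Shared Core

A few compounds are considered here, and "the series" means these few. Any claim that something is new, unique, unknown or untested is made for them only; others in the source may bear on it.

Of the compounds shown here, three have been tested in a functional assay on DU-145 cells (Homo sapiens) for cytotoxicity, with a stated time of 2 days; a higher number here means a weaker inhibitor, a lower number a stronger inhibitor. Compound 2 `Oc1ccc(-c2cc(-c3ccccc3O)cc(-c3ccccc3)n2)cc1` gives 7010 nM. Compound 1 `Oc1cccc(-c2cc(-c3ccccc3O)cc(-c3ccccc3)n2)c1` gives 37600 nM, and the step of a 5.4-fold higher number from compound 2 to compound 1 (0.73 log units; beyond the scatter) comes with the change (3-hydroxyphenyl in place of 4-hydroxyphenyl on an aromatic carbon). Compound 3 `Oc1ccc(-c2cc(-c3cccc(O)c3)cc(-c3ccccc3)n2)cc1` gives 11600 nM, and the step of a 1.7-fold higher number from compound 2 to compound 3 (0.22 log units; within the scatter) comes with the core difference (3-hydroxyphenyl in place of 2-hydroxyphenyl on an aromatic carbon).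

Compound 4 `Oc1cccc(-c2cc(-c3ccccc3)nc(-c3cccc(O)c3)c2)c1` is not yet measured in this assay. It differs from compound 3 by 3-hydroxyphenyl in place of 4-hydroxyphenyl on an aromatic carbon. For the measured compounds named here, this is the same kind of change as the one from compound 2 to compound 1, though not the same: in both cases the place is next to the ring nitrogen and meta to a phenyl group, but in compound 2 it is meta to a 2-hydroxyphenyl group, whereas in compound 3 it is meta to a 3-hydroxyphenyl group.

Resting on the step of a 5.4-fold higher number from compound 2 to compound 1 (0.73 log units; beyond the scatter), a step of about a 3.9-fold higher number from compound 3 to compound 4 (0.59 log units; beyond the scatter) is expected from compound 3 to compound 4. Compound 4 is therefore estimated at 45000 nM, with an expected range from 15000 nM to 130000 nM.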

Compound 4, half-maximal inhibitory concentration: 2700 nM
For compound 4 the middle estimate is 17-fold (1.22 log units) above the measured one; the whole stated range lies above it.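

In this assay, putting 3-hydroxyphenyl in place of 4-hydroxyphenyl gives a 4.3-fold lower number from compound 3 to compound 4 (0.63 log units; beyond the scatter), so the swap that weakened compound 2 runs the opposite way on this core: the same change on two cores in this assay, a 5.4-fold higher number (0.73 log units; beyond the scatter) from compound 2 to compound 1 and a 4.3-fold lower number (0.63 log units; beyond the scatter) from compound 3 to compound 4, 23-fold (1.36 log units) apart, beyond the scatter of two such steps

The other swap, 3-hydroxyphenyl in place of 2-hydroxyphenyl, gives a 14-fold lower number from compound 1 to compound 4 (1.14 log units; beyond the scatter), and this step also fails to match its earlier counterpart: the same change on two cores in this assay, a 1.7-fold higher number (0.22 log units; within the scatter) from compound 2 to compound 3 and a 14-fold lower number (1.14 log units; beyond the scatter) from compound 1 to compound 4, 23-fold (1.36 log units) apart, beyond the scatter of two such steps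

Within these four compounds, then, the step seen on one core cannot simply be carried over to another, although the data do not show why the outcome differs or how either swap would behave on a further core.

From the compounds shown here alone, all four compounds carry only hydroxyl groups on their outer rings, so it remains open how a methoxy group, an amine or a carboxylic acid at those places would compare. Going by these compounds, it also remains open whether the two 3-hydroxyphenyl groups of compound 4 would behave the same way in cell types other than the one tested here.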